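The source may hold more compounds than are shown below. What is called first, only, known or untested is meant among the compounds shown, and "the series" means these compounds.

Two compounds of the series carry numbers in a functional assay for inhibition of Polyunsaturated fatty acid 5-lipoxygenase (Homo sapiens); a higher number here means a weaker inhibitor, a lower number a stronger inhibitor. Compound 1 `O=C(O)/C=N/OC(CC1CCCCC1)c1ccc(OCc2ccc3ccccc3n2)cc1` gives 27 nM. Compound 2 `C/C(=N\OC(c1ccc(OCc2cscn2)cc1)C1CCCCC1)C(=O)O` gives 360 nM, the higher of the two numbers; the gap to compound 1, its nearest neighbour, lies beyond the scatter, so compound 2 is the weaker inhibitor of the pair. For the measured compounds named here, compound 1 and compound 2 differ in more than one place, so no single step between them is isolated.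

Compound 3 `C/C(=N\OC(c1ccc(OCc2nc(-c3ccccc3)cs2)cc1)C1CCCCC1)C(=O)O` has not yet been measured in this assay. It differs from compound 2 in one place: 4-phenyl-1,3-thiazol-2-yl in place of 1,3-thiazol-4-yl on a saturated chain carbon bound to an oxygen on an aromatic ring. Going by the values given here, no measured pair isolates this change. Compound 1 carries a different aromatic group on that saturated chain carbon and gives the lower number, but it also differs from compound 2 at the oxime carbon, so that comparison is only a loose guide. A moderate fall in the number, beyond the scatter, is the expected outcome, the expected step being a 3.0-fold lower number from compound 2 to compound 3 (0.48 log units; beyond the scatter). Compound 3 is estimated at 120 nM in this assay, with a range from 40 nM to 400 nM.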

Compound 3, half-maximal inhibitory concentration: 20 nM
For compound 3 the middle estimate is 6.0-fold (0.78 log units) above the measured one, outside the stated range (below it).
By their numbers in this assay, from the lowest: compounds 3 and 1 (each within the scatter of the next); then compound 2.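

In this assay, for the compounds shown here, the change from 1,3-thiazol-4-yl to 4-phenyl-1,3-thiazol-2-yl on a saturated chain carbon bound to an oxygen on an aromatic ring gives an 18-fold lower number from compound 2 to compound 3 (1.26 log units; beyond the scatter), the first step that isolates a single place. The number falls by a large margin as the group at this position grows from 5 to 11 heavy atoms and gains a six-membered aromatic ring of carbon only, while the counts of hydrogen-bond donors and acceptors stay the same, so a much larger group is accepted here in this pair. Nothing available shows what lies behind the size of this step.

The step combines two changes, the added phenyl and the move from a 1,3-thiazol-4-yl to a 1,3-thiazol-2-yl attachment, and the two compounds cannot separate their shares; an unsubstituted 1,3-thiazol-2-yl group would divide them. On these data alone, it also remains open whether the gain depends on the phenyl ring itself or would persist with a smaller methyl group or a pyridine ring in its place.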